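One Step Beyond Methylsulfanyl on a Dichloro Core

The source may report more compounds than this note shows. Statements on the series, on what has been measured and on what is new or still open speak of the compounds shown alone.

Measured in a functional assay on HCT-116 cells (Homo sapiens) for cytotoxicity, read by MTT assay, with a stated time of 48 h; on this read-out higher numbers stand for weaker inhibition of growth and lower numbers for stronger inhibition of growth:
- Compound 1 `Cc1nc2cc(Cl)c(Cl)cc2n1C1CCCC1`: 13000 nM
- Compound 2 `FC(F)(F)c1nc2cc(Cl)c(Cl)cc2n1C1CCCC1`: 22000 nM
- Compound 3 `CSc1nc2cc(Cl)c(Cl)cc2n1C1CCCC1`: 2900 nM

Of these three compounds, compound 3 gives the lowest number, 2900 nM, and so the strongest inhibition of growth. The account now turns to compound 4 `C[S+]([O-])c1nc2cc(Cl)c(Cl)cc2n1C1CCCC1`, which has not yet been measured. It keeps the shared core and changes only the group on the aromatic carbon between two ring nitrogen atoms: a group of 3 heavy atoms (1 carbon, 1 oxygen, 1 sulfur; no ring) in place of a group of 2 heavy atoms (1 carbon, 1 sulfur; no ring), on an aromatic carbon.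

Among the compounds with values here, all the measured steps concern this same place, but none involves the group that enters here. The closest guidance comes from the two steps that end at compound 3: a 4.5-fold lower number from compound 1 to compound 3 (0.65 log units; beyond the scatter) and a 7.6-fold lower number from compound 2 to compound 3 (0.88 log units; beyond the scatter). Each is modest and beyond the scatter. The remaining step, a 1.7-fold higher number from compound 1 to compound 2 (0.23 log units; within the scatter), lies within the scatter. Thus, both other groups tested here give higher numbers than methylsulfanyl, though two comparisons make a thin basis for a forecast. A modest rise in this assay is therefore expected, with weaker inhibition of growth, though the direction remains uncertain. The expected step is a 2.8-fold higher number from compound 3 to compound 4 (0.44 log units; beyond the scatter). For compound 4 the estimated value is 8000 nM, with an expected range from 2500 nM to 25000 nM.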

Compound 4, concentration for 50% growth inhibition: 500 nM
Compound 4: middle estimate off by 16-fold (1.20 log units), on the high side, and the stated range ends above it.
By their numbers in this assay, from the lowest: compound 4; then compound 3; then compounds 1 and 2 (each within the scatter of the next).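

In this assay, within the data shown here, this position between two ring nitrogen atoms still had room below methylsulfanyl, which had given the lowest number so far: the group of 3 heavy atoms (1 carbon, 1 oxygen, 1 sulfur) gives a 5.8-fold lower number from compound 3 to compound 4 (0.76 log units; beyond the scatter) in place of it. Among these compounds, measured against the other two groups, the change is larger, with a 26-fold lower number from compound 1 to compound 4 (1.41 log units; beyond the scatter) and a 44-fold lower number from compound 2 to compound 4 (1.64 log units; beyond the scatter) as the steps, and both are classed as large, whereas no step among the first three compounds was. The sulfur-bearing group that enters thus extends the range seen at this one carbon, yet nothing available here explains the gain in growth inhibition. The compounds shown leave open how methylsulfonyl, ethylsulfanyl or an amine would stand at this same carbon, and so whether the low number belongs to this one group or to a wider set of groups. They also leave open whether the step seen on the shared core would hold with a group other than cyclopentyl on the neighbouring ring atom, or with the two chlorine atoms replaced.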